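Swapping Fluoro for Methyl on a Soluble Compound

The source may hold more compounds than are shown below. What is called first, only, known or untested is meant among the compounds shown, and "the series" means these compounds.

Compound 1 `Cc1ccc(C(=O)O)c(C)c1NC(=O)c1nc(-c2cccc(CO)c2)ccc1C(F)(F)F` gives 29 ug/mL
Compound 2 `Cc1ccc(C(=O)O)c(C)c1NC(=O)c1cc(-c2cccc(CO)c2)ccc1F` gives 709 ug/mL

In a physicochemical assay for solubility, read by HPLC, with a stated time of 20 h, at pH 6 (a lower number here means a less soluble compound, a higher number a more soluble compound), compound 2 stands highest of the two compounds measured (709 ug/mL), and the gap down to compound 1 (29 ug/mL) lies beyond the usual scatter of repeated measurements. The next compound, compound 3 `Cc1ccc(-c2cccc(CO)c2)cc1C(=O)Nc1c(C)ccc(C(=O)O)c1C`, differs from compound 2 in one place (methyl in place of fluoro on an aromatic carbon): methyl in place of fluoro on an aromatic carbon, para to a 3-(hydroxymethyl)phenyl group. Going by the values given here, no two measured compounds differ in one place only, so no measured step speaks directly to this swap. Compound 2 already sits high (709 ug/mL), which leaves more room for a fall than for a rise. A modest fall in this assay is expected (a 1.8-fold lower number from compound 2 to compound 3 (0.25 log units; within the scatter)), within or close to the scatter. Compound 3 is expected at about 400 ug/mL (estimated range 120 ug/mL to 1000 ug/mL).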

Compound 3, solubility: 783 ug/mL
Compound 3: the middle estimate sits 2.0-fold (0.29 log units) below what was measured; low and high end bracket the measured number.
By their numbers in this assay, from the lowest: compound 1; then compounds 2 and 3 (each within the scatter of the next).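

In this assay the swap of methyl in place of fluoro on this aromatic carbon, para to a 3-(hydroxymethyl)phenyl group, gives a 1.1-fold higher number from compound 2 to compound 3 (0.04 log units; within the scatter) and so leaves the two compounds indistinguishable. Going by these compounds alone, this is the only measured step that isolates this position, and it shows that here, ortho to a large group, fluoro and methyl can be exchanged with no change in the read-out beyond ordinary repeat variation. Nothing given here explains this outcome.

As far as these compounds go, it remains open whether a different group on this carbon, such as an amine, a carboxylic acid or a longer chain, would move the number beyond the scatter. From the compounds shown here alone, it is also open whether the same exchange of fluoro for methyl would give a similar result on a different core.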